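A terpenoid side chain pared back to a methyl group

This account rests on a few compounds, and the source may have more. Where it says the series, first, only, none or still open, it means among the compounds named here.

Of the compounds shown here, three from one terpenoid series have been tested in a functional assay on A-375 cells (Homo sapiens) for cytotoxicity, read by MTT assay; on this read-out higher numbers stand for weaker inhibition and lower numbers for stronger inhibition. Compound 1, `CC1(C)CCC[C@]2(C)[C@@H](/C=C/c3ccoc3)C(C=O)=C(O)C(=O)[C@@H]12`, gives 21600 nM. Compound 2, `CC1=CC(=O)[C@H]2C(C)(C)CCC[C@]2(C)[C@H]1/C=C/C(=O)O`, gives 56100 nM. Compound 3, `C=C1CC[C@H]2C(C)(C)CCC[C@]2(C)[C@H]1/C=C/c1ccoc1`, gives 36600 nM. Compound 3 thus holds the second highest of the three numbers; its nearest neighbour is compound 2, whose number is higher by a margin within the usual scatter, and its furthest is compound 1, whose number is lower by a margin that also stays within that scatter. No order among the three can therefore be read from these values, and all of them sit at weak inhibition.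

Compound 4, `C=C1CC[C@H]2C(C)(C)CCC[C@]2(C)[C@H]1C`, has not yet been tested in this assay. It differs from compound 3 in one place: methyl in place of 2-(furan-3-yl)ethenyl on a saturated ring carbon. With the 2-(furan-3-yl)ethenyl group gone, compound 4 keeps the shared core of compound 3 and carries a methyl in its place. Among the measured compounds shown here, no step between measured compounds shows what this change does; the expectation can rest only on compound 3 at 36600 nM and on the narrow spread of the set. The step of a 1.6-fold higher number from compound 3 to compound 4 (0.21 log units; within the scatter) is expected to be modest and toward a higher number, and it may well fall within the scatter. Compound 4 is estimated at 60000 nM, with a range from 25000 nM to 150000 nM.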

Compound 4, half-maximal inhibitory concentration: 50200 nM
Estimate against measurement, compound 4: 1.2-fold (0.08 log units) above; the measured number falls inside the stated range.
By their numbers in this assay, from the lowest: compounds 1, 3, 4 and 2 (each within the scatter of the next, the first and the last beyond it).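

Paring the side chain back gives the first direct reading at this position: in this assay the exchange of 2-(furan-3-yl)ethenyl for methyl on a saturated ring carbon gives a 1.4-fold higher number from compound 3 to compound 4 (0.14 log units; within the scatter) on this read-out. The five-membered aromatic ring, the double bond outside it and the hydrogen-bond acceptor all leave with that group, yet the numbers of the two compounds stay within the scatter of each other, so this large structural change does not separate them, and the side chain of compound 3 shows no measurable contribution to this weak inhibition. Nothing available on either compound accounts for this outcome.

The compounds shown leave open whether any other group on this ring carbon, such as a primary amine or a longer saturated alkyl chain, would move the number beyond the scatter of the value for compound 3. As far as these compounds go, it also remains open whether the same exchange of 2-(furan-3-yl)ethenyl for methyl on the core of compound 1 would give a step of similar size.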